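From Dimethylphenyl to Acetylphenyl: an Untested Step

A few compounds are considered here, and "the series" means these few. Any claim that something is new, unique, unknown or untested is made for them only; others in the source may bear on it.

Measured so far in a functional assay on HeLa cells (Homo sapiens) for inhibition, read by CCK-8 assay, with a stated time of 48 h; a higher number here means a weaker inhibitor, a lower number a stronger inhibitor:
compound 1 `COc1cc(-c2ccnc3cc(-c4ccc(F)cc4)nn23)cc(OC)c1OC` gives 5840 nM
compound 2 `COc1cc(-c2ccnc3cc(-c4ccc(C)c(C)c4)nn23)cc(OC)c1OC` gives 241 nM
compound 3 `COc1cc(-c2ccnc3cc(-c4ccc5c(ccn5C)c4)nn23)cc(OC)c1OC` gives 19 nM

Compound 2 sits second highest of the three numbers in this assay. Its nearest neighbour is compound 3, reached by a 13-fold lower number from compound 2 to compound 3 (1.10 log units; beyond the scatter); its furthest is compound 1, from which it is separated by a 24-fold lower number from compound 1 to compound 2 (1.38 log units; beyond the scatter). The remaining step, a 310-fold lower number from compound 1 to compound 3 (2.49 log units; beyond the scatter), shows how far the group on this aromatic carbon has moved the read-out within this small set.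

Compound 4 `COc1cc(-c2ccnc3cc(-c4ccc(C(C)=O)cc4)nn23)cc(OC)c1OC` has not yet been measured. Its difference from compound 2 is 4-acetylphenyl in place of 3,4-dimethylphenyl on an aromatic carbon. None of the three measured steps exchanges a hydrocarbon aryl group for one carrying a hydrogen-bond acceptor, so they bear on this change only by showing that substitution at this position shifts the number by large amounts in either direction. Within the data shown here, with no direct precedent, the expectation is a step in the direction of a higher number, of moderate size, and with wide uncertainty: a 2.5-fold higher number from compound 2 to compound 4 (0.40 log units; beyond the scatter). The estimate for compound 4 in this assay is 600 nM, expected to fall between 100 nM and 3500 nM.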

Compound 4, half-maximal inhibitory concentration: 1810 nM
For compound 4 the middle estimate is 3.0-fold (0.48 log units) below the measured one; measured number inside the range.
By their numbers in this assay, from the lowest: compound 3; then compound 2; then compound 4; then compound 1.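

In this assay, among these compounds, the first group at this carbon to carry a hydrogen-bond acceptor gave a 7.5-fold higher number from compound 2 to compound 4 (0.88 log units; beyond the scatter), so 4-acetylphenyl does not hold the level of 3,4-dimethylphenyl. The acetyl group still improves on fluoro at the same place on the phenyl ring, with a 3.2-fold lower number from compound 1 to compound 4 (0.51 log units; beyond the scatter), while the 1-methyl-1H-indol-5-yl group of compound 3 stays far ahead, as a 95-fold higher number from compound 3 to compound 4 (1.98 log units; beyond the scatter) shows. Nothing available explains why the number moves in these directions, so the steps stand here as observations only.

The compounds shown leave open whether the rise from compound 2 to compound 4 goes with the arrival of the acetyl group or with the departure of the methyl groups of 3,4-dimethylphenyl, since the exchange does both at once. A 4-methylphenyl group would help separate the two, and a 4-aminophenyl or 4-carboxyphenyl group would show how other replacements at this carbon compare with acetyl.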